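The compounds below may be only part of what the source reports. "The series", "measured", "known", "first", "only" and "open" are said of these compounds alone.

Measured so far in an ADME assay on MT4 cells (Homo sapiens) for cytotoxicity, read by MTT assay; a higher number here means that more compound is tolerated, a lower number that less compound is tolerated:
- compound 1 `COc1ccc(/C=N/NC(=O)CSc2nnnn2-c2cccc3ccccc23)cc1`: compound 1 gives > 298000 nM, a limit of the assay
- compound 2 `COc1cc(/C=N/NC(=O)CSc2nnnn2-c2cccc3ccccc23)ccc1O`: compound 2 gives > 287000 nM, also a limit

Compound 2 stands at the limit of > 287000 nM in this assay, at which 1 of the 2 values shown sits; compound 1 stands at the limit of > 298000 nM in this assay, at which 1 of the 2 values shown sits. Among the compounds with values here, the one measured step, a step that the two limits leave unreadable from compound 1 to compound 2, is therefore unreadable in size.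

Compound 3 `CN(C)c1ccc(/C=N/NC(=O)CSc2nnnn2-c2cccc3ccccc23)cc1` differs from compound 2 in one place: 4-(dimethylamino)phenyl in place of 4-hydroxy-3-methoxyphenyl on a carbon with a double bond to nitrogen. Only the unreadable step bears on this change, so no size and no direction can be taken from it. Compound 3 is expected to sit again at a limit, estimated at 280000 nM (range 100000 nM to 320000 nM). The expected step of an at least 1.0-fold lower number from compound 2 to compound 3 (0.01 log units; that floor lies within the scatter) stays within the scatter.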

Compound 3, half-maximal cytotoxic concentration: > 289000 nM
Compound 3 gave a limit, no number (the forecaster's own chance of this, stated with the estimate: 75%); middle value at least 1.0-fold (0.01 log units) from the limit.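

In this assay compound 3 gives > 289000 nM, a limit of the assay. Within the data shown here, compound 1 and compound 2 also stand at limits, so no step among the three can be read. The concentration at which any of these compounds stops being tolerated stays open.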